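A few compounds are considered here, and "the series" means these few. Any claim that something is new, unique, unknown or untested is made for them only; others in the source may bear on it.

Measured in a functional assay on MDA-MB-231 cells (Homo sapiens) for antiproliferative activity, read by MTT assay, with a stated time of 24 h; on this read-out higher numbers stand for weaker inhibition and lower numbers for stronger inhibition:
- compound 1 `CCCCNC(=O)CCCOc1ccc(C(=O)c2c(CCCC)oc3ccccc23)cc1`: 38100 nM
- compound 2 `CCCCc1oc2ccccc2c1C(=O)c1ccc(OCCCC(=O)NCc2ccccc2)cc1`: > 50000 nM (a limit)

Compound 2 reads > 50000 nM, which is a limit and not a number: the limit of > 50000 nM in this assay, at which 1 of the 2 values shown sits.

The next structure is compound 3 `CCCCc1oc2ccccc2c1C(=O)c1ccc(OCCCC(=O)N[C@H](C)c2ccccc2)cc1`. The change is methyl in place of hydrogen on a saturated chain carbon bound to an amide-type nitrogen and an aromatic carbon, which takes benzyl to 1-phenylethyl.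

Within the data shown here, no measured step adds this methyl. Among the measured compounds shown here, the only measured step on the same amide side chain is an at least 1.3-fold higher number from compound 1 to compound 2 (0.11 log units; that floor lies within the scatter), and its floor lies within the scatter. On the strength of that step, no change beyond the scatter is expected in this assay, in either direction, and another limit reading is quite possible.

The estimated step is a number no higher from compound 2 to compound 3 (the limit leaves the size open). For compound 3 the expected value is 50000 nM. The estimated range runs from 22000 nM to 110000 nM.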

Compound 3, half-maximal inhibitory concentration: > 50000 nM
Compound 3: only a limit was reported; the forecaster's own chance of this, stated with the estimate: 55%; the middle value lies on the limit itself.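

Benzyl to 1-phenylethyl leaves compound 3 at a limit, > 50000 nM in this assay, and the step from compound 2 cannot be read: both ends are limits. 1-Phenylethyl in place of butyl on the amide-type nitrogen gives an at least 1.3-fold higher number from compound 1 to compound 3 (0.11 log units; that floor lies within the scatter), so this reading fixes no difference beyond the scatter. Readings on this amide side chain now gather largely at one value: the limit of > 50000 nM in this assay, at which 2 of the 3 values shown sit.

On these data alone, what methyl in place of hydrogen at this carbon does on a compound with a readable number stays open. Also open, as far as these compounds go, is whether a longer chain in place of butyl on the amide-type nitrogen, or a chain carrying an amine or a carboxylic acid, would give a number clearly lower than that of compound 1.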